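Ortho-fluoro on the benzyl group of a cyclopropylamino analogue

A few compounds are considered here, and "the series" means these few. Any claim that something is new, unique, unknown or untested is made for them only; others in the source may bear on it.

Measured compounds in an assay on Cerebral cortex for displacement of a labelled ligand from adenosine receptor A1 (Bos taurus); a lower number here means a stronger inhibitor, a higher number a weaker inhibitor:
compound 1 `CNc1nc(-c2ccccc2)nc2c1nnn2Cc1ccccc1F` gives 25 nM
compound 2 `CCCCCCNc1nc(-c2ccccc2)nc2c1nnn2Cc1ccccc1F` gives 25 nM
compound 3 `c1ccc(Cn2nnc3c(NC4CC4)nc(-c4ccccc4)nc32)cc1` gives 11.3 nM

Compound 3 holds the lowest number of the three. Compound 4 `Fc1ccccc1Cn1nnc2c(NC3CC3)nc(-c3ccccc3)nc21` differs from compound 3 by fluoro in place of hydrogen on an aromatic carbon. Within the data shown here, no measured pair differs by this change alone; the only one-place step recorded, no change at the digits printed from compound 1 to compound 2 (within the scatter), concerns the chain on the amine nitrogen and not the fluoro. Compounds 1 and 2 already carry the 2-fluorobenzyl group and sit close to compound 3, so the fluoro is expected to shift this assay little. For compound 4 a step of a 1.1-fold lower number from compound 3 to compound 4 (0.05 log units; within the scatter) is therefore estimated, within the scatter. Compound 4 is expected to give 10 nM, in the range 4 nM to 25 nM.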

Compound 4, inhibition constant: 15 nM
The estimate for compound 4 lay 1.5-fold (0.18 log units) below the measured number; measured number inside the range.
By their numbers in this assay, from the lowest: compounds 3, 4, 1 and 2 (each within the scatter of the next, the first and the last beyond it).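

In this assay, among these compounds, fluoro in place of hydrogen on the benzyl group gives a 1.3-fold higher number from compound 3 to compound 4 (0.12 log units; within the scatter) and this is the first pair to isolate that change, so on the cyclopropylamino analogue the fluoro leaves the number within the scatter. With the 2-fluorobenzyl group held, the amine substituent behaves alike: the change gives a 1.7-fold lower number from compound 1 to compound 4 (0.22 log units; within the scatter) and a 1.7-fold lower number from compound 2 to compound 4 (0.22 log units; within the scatter) in turn. No evidence bears on these results. Open, as far as these compounds go, is how chloro or methoxy would read on that aromatic carbon, and whether fluoro in place of hydrogen would give a similar step on the methyl or hexyl analogue.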